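The source may hold more compounds than are shown below. What is called first, only, known or untested is meant among the compounds shown, and "the series" means these compounds.

Measured in a functional assay on cells (Leukemia cell, Homo sapiens) for cytotoxicity, with a stated time of 48 h; on this read-out higher numbers stand for weaker inhibition of growth and lower numbers for stronger inhibition of growth:
- compound 1 `COc1ccc(CN2C(=O)/C(=C\c3cc(OC)c(OC)c(OC)c3)c3ccccc32)cc1`: 2200 nM
- compound 2 `COc1cc(/C=C2/C(=O)N(C)c3ccc(O)cc32)cc(OC)c1OC`: 2200 nM
- compound 3 `COc1ccc2c(c1)/C(=C\c1cc(OC)c(OC)c(OC)c1)C(=O)N2C`: 1400 nM

Compound 1, at 2200 nM, gives the same number as compound 2 and lies within the usual scatter of compound 3, so it holds no clear rank among the three. Compound 4 `COc1cc(/C=C2\C(=O)N(Cc3ccc(Cl)cc3)c3ccccc32)cc(OC)c1OC` has chloro in place of methoxy on an aromatic carbon, para to a large group, which turns 4-methoxybenzyl into 4-chlorobenzyl (chloro in place of methoxy on an aromatic carbon). For the measured compounds named here, the only measured step, a 1.6-fold lower number from compound 2 to compound 3 (0.20 log units; within the scatter), places methyl in place of hydrogen on an oxygen on an aromatic ring. That step stays within the scatter, but it does not involve this group, so it offers only weak guidance. No step beyond the scatter is therefore expected in this assay, in either direction, and the estimated change is a 1.1-fold lower number from compound 1 to compound 4 (0.04 log units; within the scatter). Compound 4 is expected at 2000 nM, with an estimated range of 900 nM to 4500 nM.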

Compound 4, concentration for 50% growth inhibition: 1500 nM
For compound 4 the middle estimate is 1.3-fold (0.12 log units) above the measured one, and the stated range covers the measured number.
By their numbers in this assay, from the lowest: compounds 3, 4, 1 and 2 (each within the scatter of the next).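

In this assay, replacing 4-methoxybenzyl with 4-chlorobenzyl gives a 1.5-fold lower number from compound 1 to compound 4 (0.17 log units; within the scatter) and so leaves the read-out without a clear shift. The earlier step changed a different group, whereas this one shows that this aromatic carbon tolerates chloro in place of methoxy with no change beyond the scatter. Nothing available explains this result or ties it to either group. Still open, from the compounds shown here alone, is whether an amine or a carboxylic acid on the same aromatic carbon would move the number beyond the scatter. Also open, going by these compounds, is whether a step of any size can be found here at all.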